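From 2,6-dichlorophenyl to 2,3-dichlorophenyl in the series

A few compounds are considered here, and "the series" means these few. Any claim that something is new, unique, unknown or untested is made for them only; others in the source may bear on it.

In a functional assay on PC-3 cells (Homo sapiens) for inhibition, read by MTT assay, with a stated time of 48 h, tested at 10 uM (a higher number here means more inhibition of growth at the concentration tested, a lower number less inhibition of growth), compound 1 `Cc1cc(=O)c2c(O)cc(OCc3ccccc3)c([C@H]3CCN(C)C[C@H]3O)c2o1` gives 41% and compound 2 `Cc1cc(=O)c2c(O)cc(OCc3ccccc3Br)c([C@H]3CCN(C)C[C@H]3O)c2o1` gives 32%. Compound 3 `Cc1oc2c([C@H]3CCN(C)C[C@H]3O)c(O)cc(O)c2c(=O)c1C(O)c1c(Cl)cccc1Cl` stands lowest of the three at 0%, beyond the scatter from both of the others. Compound 4 `Cc1oc2c([C@H]3CCN(C)C[C@H]3O)c(O)cc(O)c2c(=O)c1C(O)c1cccc(Cl)c1Cl` has not yet been measured. Its change is 2,3-dichlorophenyl in place of 2,6-dichlorophenyl on a saturated chain carbon bound to an aromatic carbon and an oxygen on a saturated carbon.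

Among the measured compounds shown here, only one measured step bears on this, and only loosely: a number 9 percentage points lower from compound 1 to compound 2 (within the scatter), a bromo in place of hydrogen on an aromatic carbon, stays within the scatter. For the measured compounds named here, no measured pair moves a chlorine, so the evidence for this exchange is thin. A small size of step is therefore expected, with any movement upward from the value of compound 3 at 0%. The expected step is a number 8 percentage points higher from compound 3 to compound 4 (within the scatter), which would not clearly leave the scatter. For compound 4 the estimated value is 8%, with an expected range of 0% to 28%.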

Compound 4, percent growth inhibition at one concentration: 20%
Compound 4: the middle estimate sits 12 percentage points below what was measured; measured number inside the range.
By their numbers in this assay, from the lowest: compound 3; then compound 4; then compounds 2 and 1 (each within the scatter of the next).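

In this assay the exchange of 2,6-dichlorophenyl for 2,3-dichlorophenyl gives a number 20 percentage points higher from compound 3 to compound 4 (beyond the scatter) with the atoms of the group unchanged and only their arrangement different. At this place on the saturated chain carbon, the arrangement of the two chlorines therefore matters to growth inhibition at the concentration tested, and not merely their presence. Nothing measured here accounts for the difference.

With only these two chlorine patterns shown, it stays open whether the step reflects loss of the 2,6-dichlorophenyl pattern or a gain specific to 2,3-dichlorophenyl. On these data alone, how an unsubstituted phenyl, or a phenyl bearing a methoxy group, would read at this place also stays open, as does any link to compound 1 and compound 2, which differ from this pair in more than one place.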